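The source may hold more compounds than are shown below. What is called first, only, known or untested is meant among the compounds shown, and "the series" means these compounds.

Measured compounds:
Compound 1, `COc1cc(Cl)c(C(=O)Nc2cccc(-c3nc4ccccc4s3)c2)cc1[N+](=O)[O-]`. In an ADME assay on HEK293 cells (Homo sapiens) for cytotoxicity, with a stated time of 72 h (a higher number here means that more compound is needed for the effect, a lower number that less compound is needed), compound 1 gives > 25000 nM, which is a limit of this assay and not a number.
Compound 2, `O=C(Nc1cccc(-c2nc3ccccc3s2)c1)c1cc([N+](=O)[O-])c(O)cc1Cl`. In this assay compound 2 gives > 25000 nM, again only a limit.
Compound 3, `O=C(Nc1cccc(-c2nc3ccccc3s2)c1)c1cc([N+](=O)[O-])ccc1Cl`. In this assay compound 3 gives > 27000 nM, a limit as well.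

Going by the values given here, compound 3 therefore stands nowhere in particular: every value in the set is a limit, and no compound can be ranked against another. The three single-point changes among them, a step that the two limits leave unreadable from compound 1 to compound 2, a step that the two limits leave unreadable from compound 1 to compound 3 and a step that the two limits leave unreadable from compound 2 to compound 3, are each unreadable for the same reason; the limit of > 25000 nM in this assay, at which 2 of the 3 values shown sit, and the limit of > 27000 nM in this assay, at which 1 of the 3 values shown sits, are all the evidence there is.

Compound 4, `O=C(O)COc1cc(Cl)c(C(=O)Nc2cccc(-c3nc4ccccc4s3)c2)cc1[N+](=O)[O-]`, is not yet measured. It differs from compound 3 by carboxymethoxy in place of hydrogen on an aromatic carbon.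

Among the compounds with values here, no measured step bears readably on this change, since all three steps in the set are hidden by limits. Nothing in the data points to a step in either direction beyond the scatter, so for this assay the expectation for the step that the limit leaves unreadable from compound 3 to compound 4 is none beyond the scatter, and compound 4 is expected to return a limit as well. The estimate for compound 4 is 30000 nM, within 15000 nM to 60000 nM.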

Compound 4, half-maximal effective concentration: > 25000 nM
Compound 4 ended at the assay's limit; the forecaster's own chance of this, stated with the estimate: 85%; the middle value lies beyond the limit too.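

In this assay compound 4 gives > 25000 nM, which is a limit and not a number. None of the steps from compound 1, compound 2 and compound 3 to compound 4 can be read: all four values are limits. The compounds shown leave open at what concentration any of the four reaches the effect, and whether carboxymethoxy changes it.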